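Replacing the amide with an imine on the shared core

This account rests on a few compounds, and the source may have more. Where it says the series, first, only, none or still open, it means among the compounds named here.

In a functional assay on Ehrlich cells (Mus musculus) for cytotoxicity, read by trypan blue exclusion, with a stated time of 2 h (a lower number here means a stronger inhibitor, a higher number a weaker inhibitor), compound 1 `CC(Cl)CC(=O)NC1=C(C#N)C(c2ccc(Cl)cc2Cl)C2=C(CCCC2=O)N1c1ccc(S(N)(=O)=O)cc1` gives 25 ug/mL. Compound 2 `N#CC1=C(NC(=O)C2CC2)N(c2ccc(S(N)(=O)=O)cc2)C2=C(C(=O)CCC2)C1c1ccc(Cl)cc1Cl` gives 75 ug/mL in this assay, which is a 3.0-fold higher number from compound 1 to compound 2 (0.48 log units; beyond the scatter). Compound 3 `Cc1ccc(C(=O)NC2=C(C#N)C(c3ccc(Cl)cc3Cl)C3=C(CCCC3=O)N2c2ccc(S(N)(=O)=O)cc2)cc1` sits at the limit of > 100 ug/mL in this assay, at which 1 of the 3 values shown sits, in this assay, so its value of > 100 ug/mL is a limit and not a number. For that reason an at least 4.0-fold higher number from compound 1 to compound 3 (0.60 log units; beyond the scatter) is known only as a floor, and the floor of an at least 1.3-fold higher number from compound 2 to compound 3 (0.12 log units; that floor lies within the scatter) is too small to read as a change.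

Compound 4 `CN(C)c1ccc(/C=N/C2=C(C#N)C(c3ccc(Cl)cc3Cl)C3=C(CCCC3=O)N2c2ccc(S(N)(=O)=O)cc2)cc1` differs from compound 3 by a group of 11 heavy atoms (9 carbon, 2 nitrogen; one six-membered aromatic ring of carbon only) in place of a group of 10 heavy atoms (8 carbon, 1 nitrogen, 1 oxygen; one six-membered aromatic ring of carbon only), on a double-bonded ring carbon. Among the compounds with values here, no measured step alters this part of the core in the same way; the three measured steps only exchange the group on the carbonyl carbon, and the widest of them is an at least 4.0-fold higher number from compound 1 to compound 3 (0.60 log units; beyond the scatter). Compound 3 stands at the weak end of the shown numbers, with only a limit to its name. The expected step of a number no higher from compound 3 to compound 4 (the limit leaves the size open) is therefore small and uncertain in direction, since an at least 4.0-fold higher number from compound 1 to compound 3 (0.60 log units; beyond the scatter) already runs toward weaker inhibition in this region. Compound 4 is expected to give about 100 ug/mL in this assay, somewhere between 30 ug/mL and 300 ug/mL, with a real chance that only a limit is reported.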

Compound 4, half-maximal inhibitory concentration: > 100 ug/mL
Compound 4 gave a limit, no number; the forecaster's own chance of this, stated with the estimate: 55%; the middle value lies on the limit itself.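

In this assay, the exchange of the ((4-methylphenyl)carbonyl)amino group, which carries 1 hydrogen-bond donor, for an imine group with 0 hydrogen-bond donors and 2 hydrogen-bond acceptors is the first change shown to the link on this double-bonded ring carbon, and compound 4 gives a limit rather than a number, as compound 3 did: the limit of > 100 ug/mL in this assay, at which 2 of the 4 values shown sit. The step between these two compounds cannot be read, so the data show neither a gain nor a loss from replacing the amide with the imine, only that this imine, like the 4-methylphenyl amide, gives no number in the assay. Against the two compounds with numbers, the result places compound 4 with the 4-methylphenyl amide: an at least 4.0-fold higher number from compound 1 to compound 4 (0.60 log units; beyond the scatter) is beyond the scatter, whereas an at least 1.3-fold higher number from compound 2 to compound 4 (0.12 log units; that floor lies within the scatter) is too small to read as a change.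

The compounds shown leave open whether any imine at this position would give a number, for instance one carrying an unsubstituted phenyl ring or a short alkyl chain. They also leave open how a free amine on this ring carbon, or a plain propyl amide without the chlorine, would compare with compound 1.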